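The source may hold more compounds than are shown below. What is called first, only, known or untested is meant among the compounds shown, and "the series" means these compounds.

Three related compounds have been measured in a functional assay on the whole organism for inhibition, with Rattus norvegicus as the target, with stated times of 1 h and 3.5 h, at a dose of 100 mg/kg by the oral route (on this read-out lower numbers stand for less inhibition and higher numbers for more inhibition at the one dose given (going by the name of the read-out)), and a fourth awaits its turn. Compound 1, with the structure `c1cc(-c2ccncn2)ccn1`, gives 45%. Compound 2, with the structure `Cc1cncnc1-c1ccncc1`, gives 50%. Compound 3, with the structure `Cc1ncc(-c2ccccc2)c(C(C)(C)C)n1`, gives 22%, the lowest of the three; its nearest neighbour is compound 1 and its furthest is compound 2, both beyond the scatter.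

Compound 2 and compound 1 differ in one place, and that difference is hydrogen in place of methyl on an aromatic carbon. The matching step in this assay is a number 5 percentage points lower from compound 2 to compound 1 (within the scatter), which lies within the scatter.

Compound 4, with the structure `CC(C)(C)c1ncncc1-c1ccccc1`, has not yet been measured. It is related to compound 3 by hydrogen in place of methyl on an aromatic carbon. This is the same kind of change as that from compound 2 to compound 1, but the place is not the same: in compound 2 the methyl sits ortho to a group of 6 heavy atoms and two atoms from the ring nitrogen, whereas in compound 3 it sits between two ring nitrogen atoms, meta to a tert-butyl group and para to a group of 6 heavy atoms. The difference between the core of compound 3 and the core of compound 2 is not broken down here.

Resting on the single earlier example, where the removal of the methyl gave a number 5 percentage points lower from compound 2 to compound 1 (within the scatter), the expected step for compound 4 is a number 2 percentage points lower from compound 3 to compound 4 (within the scatter). The estimate for compound 4 in this assay is therefore 20%, expected to fall between 5% and 38%.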

Compound 4, a percentage reported as inhibition, in the whole organism at one dose (the size of the read-out at that dose, not a potency): 48%
Compound 4: the middle estimate sits 28 percentage points below what was measured; measured number outside the range, above it.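

In this assay, putting hydrogen in place of the methyl on the core of compound 3 gives a number 26 percentage points higher from compound 3 to compound 4 (beyond the scatter). The same swap on a different core gave a much different result, so in this series the step seen on one core cannot simply be carried over to another: the same change on two cores in this assay, a number 5 percentage points lower (within the scatter) from compound 2 to compound 1 and a number 26 percentage points higher (beyond the scatter) from compound 3 to compound 4, 31 percentage points apart, beyond the scatter of two such steps. This shows that the outcome of removing this methyl depends on where it is removed, but not why: the two pairs differ both in their cores and in the place of the methyl, which on compound 3 sits between two ring nitrogen atoms, and two steps cannot separate those influences or reveal a mechanism.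

The compounds shown carry only methyl or hydrogen at that place between the two ring nitrogen atoms, so it remains open what an amine, a methoxy group or a longer chain there would give in this assay. As far as these compounds go, it also remains open whether the same swap on a further core would follow the step seen from compound 3 to compound 4, the step seen from compound 2 to compound 1, or neither.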